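Replacing the trimethoxyphenyl on the acrylamide of compound 3

A few compounds are considered here, and "the series" means these few. Any claim that something is new, unique, unknown or untested is made for them only; others in the source may bear on it.

Of the compounds shown here, three sharing one core have been measured in a functional assay on HT-29 cells (Homo sapiens) for cytotoxicity, read by MTT assay, with a stated time of 72 h; a lower number here means a stronger inhibitor, a higher number a weaker inhibitor. Compound 1 `COc1ccc(C(=O)c2cc(OC)c(OC)c(OC)c2)cc1NC(=O)/C=C/c1cc(OC)c(OC)c(OC)c1` gives 3100 nM. Compound 2 `COc1ccc(C(=O)c2cc(OC)c(OC)c(OC)c2)cc1NC(=O)/C=C/c1cccc(OC(F)(F)F)c1` gives 5200 nM, and a 1.7-fold higher number from compound 1 to compound 2 (0.22 log units; within the scatter). Compound 3 `COc1cc(C(=O)c2cc(OC)c(OC)c(OC)c2)cc(NC(=O)/C=C/c2cc(OC)c(OC)c(OC)c2)c1OC` gives 3100 nM, and no change at the digits printed from compound 1 to compound 3 (within the scatter). Compound 3 therefore stands level with compound 1 at the digits shown, the two of them sharing the lowest number among the three, with compound 2 the furthest away and still within the scatter.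

Compound 4 `COc1cc(C(=O)c2cc(OC)c(OC)c(OC)c2)cc(NC(=O)/C=C/c2cc(F)c(F)c(F)c2)c1OC` has not yet been measured. It differs from compound 3 in one place: 3,4,5-trifluorophenyl in place of 3,4,5-trimethoxyphenyl on a double-bonded chain carbon bound to a double-bonded chain carbon. Going by the values given here, the only measured step that touches the same position is the one from compound 1 to compound 2, where the 3,4,5-trimethoxyphenyl also left the double-bonded chain carbon and a fluorine-bearing aryl took its place; that step was small and within the scatter. Compound 4 is therefore expected to land close to compound 3, with at most a modest rise in the number, so that a 1.5-fold higher number from compound 3 to compound 4 (0.16 log units; within the scatter) is the expected step. Compound 4 is estimated at 4500 nM, with a range from 1500 nM to 14000 nM.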

Compound 4, half-maximal inhibitory concentration: 3300 nM
Estimate against measurement, compound 4: 1.4-fold (0.13 log units) above; the range from low to high includes it.
By their numbers in this assay, from the lowest: compounds 1, 3, 4 and 2 (each within the scatter of the next).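

Across the 3,4,5-trimethoxyphenyl to 3,4,5-trifluorophenyl swap on a double-bonded chain carbon bound to a double-bonded chain carbon, this assay shows a 1.1-fold higher number from compound 3 to compound 4 (0.03 log units; within the scatter), so the number stays within the scatter even though the entering aryl carries no oxygen at all. This goes further than the earlier change at this position. Compound 2 still kept an oxygen in its trifluoromethoxy group and sat on the core of compound 1, whereas here the full exchange is read on the core of compound 3, with 12 heavy atoms and 3 hydrogen-bond acceptors leaving, and 9 heavy atoms and 0 hydrogen-bond acceptors entering. No measurement shown here offers an explanation for this result.

All four compounds lie within the scatter of their neighbours in the ranking, so nothing here shows which kind of group at this position would shift the number beyond the scatter. On these data alone, it stays open whether an amine or a carboxylic acid on this aryl, or a longer chain in its place, would leave the number where it is.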